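A few compounds are considered here, and "the series" means these few. Any claim that something is new, unique, unknown or untested is made for them only; others in the source may bear on it.

Of the compounds shown here, three sharing one core have been measured in a functional assay on aorta (Rattus norvegicus, strain Sprague-Dawley) for inhibition; a lower number here means that less compound is needed, a higher number that more compound is needed for the effect. Compound 1 (`CCCOc1cc2c(c3c1C[C@@H]1[C@@H](C)CO[C@]1(C)O3)C[C@@H]1[C@@H](C)CO[C@]1(C)O2`), carrying propoxy, gives 77000 nM. Compound 2 (`Cc1cc2c(c3c1C[C@@H]1[C@@H](C)CO[C@]1(C)O3)C[C@@H]1[C@@H](C)CO[C@]1(C)O2`), carrying methyl, gives 52000 nM. Compound 3 (`COc1cc2c(c3c1C[C@@H]1[C@@H](C)CO[C@]1(C)O3)C[C@@H]1[C@@H](C)CO[C@]1(C)O2`), carrying methoxy, gives 33000 nM. Compound 3 stands level with compound 2, as a 1.6-fold lower number from compound 2 to compound 3 (0.20 log units; within the scatter) shows, while its distance from compound 1 goes beyond the scatter.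

Compound 4 (`C=C=CCOc1cc2c(c3c1C[C@@H]1[C@@H](C)CO[C@]1(C)O3)C[C@@H]1[C@@H](C)CO[C@]1(C)O2`) follows from compound 3 by propa-1,2-dien-1-yl in place of hydrogen on a saturated chain carbon bound to an oxygen on an aromatic ring, with propa-1,2-dien-1-yl in place of hydrogen on a saturated chain carbon bound to an oxygen on an aromatic ring. Among the compounds with values here, the one measured step at this carbon exchanges ethyl for hydrogen, and it is modest: a 2.3-fold lower number from compound 1 to compound 3 (0.37 log units; beyond the scatter). Read backwards, it suggests that a chain added here may raise the number by a similar small amount, although no measured compound has a chain with double bonds at this place. The expected change is a 1.8-fold higher number from compound 3 to compound 4 (0.26 log units; within the scatter). For compound 4, the estimated value is 60000 nM, with an expected range from 25000 nM to 140000 nM.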

Compound 4, half-maximal effective concentration: 11000 nM
Compound 4: the middle estimate sits 5.5-fold (0.74 log units) above what was measured; measured number outside the range, below it.
By their numbers in this assay, from the lowest: compound 4; then compounds 3, 2 and 1 (each within the scatter of the next, the first and the last beyond it).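

In this assay, a group added at the saturated chain carbon bound to an oxygen on an aromatic ring need not raise the number: ethyl there goes with a higher number, whereas propa-1,2-dien-1-yl goes with a lower one (a 3.0-fold lower number from compound 3 to compound 4 (0.48 log units; beyond the scatter)). Exchanging one of these groups for the other at this carbon gives the widest step in the set (a 7.0-fold lower number from compound 1 to compound 4 (0.85 log units; beyond the scatter)), so the kind of group matters here and not merely the presence of one. The (buta-2,3-dien-1-yl)oxy group also stands clear of methyl on the aromatic carbon (a 4.7-fold lower number from compound 2 to compound 4 (0.67 log units; beyond the scatter)).

The data offer no measurement that accounts for this difference between the groups. Going by these compounds, whether the double bonds or the chain itself carry the step remains open, and a saturated butoxy group in the same place would bear on that.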